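The source may hold more compounds than are shown below. What is called first, only, known or untested is meant among the compounds shown, and "the series" means these compounds.

Compound 2 `O=C(CSc1nnc(-c2ccncc2)o1)N/N=C/c1cc(Br)ccc1O` carries the shared core with a 5-bromo-2-hydroxyphenyl on the carbon with a double bond to nitrogen. In a functional assay on MCF7 cells (Homo sapiens) for cytotoxicity, read by MTT assay, with a stated time of 48 h (on this read-out higher numbers stand for weaker inhibition and lower numbers for stronger inhibition), compound 2 gives 7770 nM. Within the data shown here, its only measured neighbour, compound 1 `O=C(CSc1nnc(-c2ccncc2)o1)N/N=C/c1ccccc1`, which bears a plain phenyl at that carbon, gives 14600 nM in this assay, and the two values lie within the scatter of each other, as the step of a 1.9-fold lower number from compound 1 to compound 2 (0.27 log units; within the scatter) shows.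

Compound 3 `O=C(CSc1nnc(-c2ccncc2)o1)N/N=C/c1cc(Cl)cc(Cl)c1O` differs from compound 2 in one place: 3,5-dichloro-2-hydroxyphenyl in place of 5-bromo-2-hydroxyphenyl on a carbon with a double bond to nitrogen. Among the measured compounds shown here, the one step that bears on this change is the one from compound 1 to compound 2, in which a halogen and a hydroxyl entered the same aromatic ring on the same carbon, and that step stayed within the scatter. Further substitution of the same ring with chlorine in the place of bromine, with a second chlorine added, is therefore expected to move the number little, if at all, and the step of a 1.2-fold lower number from compound 2 to compound 3 (0.08 log units; within the scatter) is estimated to stay within the scatter. Compound 3 is thus expected to give about 6500 nM in this assay, with a range from 2500 nM to 17000 nM.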

Compound 3, half-maximal inhibitory concentration: 5920 nM
The estimate for compound 3 lay 1.1-fold (0.04 log units) above the measured number; the range from low to high includes it.
By their numbers in this assay, from the lowest: compounds 3, 2 and 1 (each within the scatter of the next, the first and the last beyond it).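

In this assay, exchanging 5-bromo-2-hydroxyphenyl for 3,5-dichloro-2-hydroxyphenyl on the carbon with a double bond to nitrogen gives a 1.3-fold lower number from compound 2 to compound 3 (0.12 log units; within the scatter) and so leaves these two substituted rings indistinguishable at this position. Among these compounds, the new information lies in the comparison with the plain phenyl: a 2.5-fold lower number from compound 1 to compound 3 (0.39 log units; beyond the scatter) is the only step at this carbon that passes the scatter, and only modestly, while a 1.9-fold lower number from compound 1 to compound 2 (0.27 log units; within the scatter) does not, so the separation from phenyl is clear for the dichloro ring alone and cannot be credited to the exchange of halogens itself. The data shown offer no measurement that would explain these numbers.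

As far as these compounds go, in both substituted compounds the hydroxyl and the halogen enter the ring together, so it remains open whether either one alone, such as a ring bearing only the hydroxyl or only a chlorine, would give the same reading. Also open, from the compounds shown here alone, is how this assay would read with a methoxy group in place of that hydroxyl, or with an amine or a carboxylic acid on the same ring.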